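Trifluoromethoxy in Place of Carbamoyl: An Expected Shift

This account rests on a few compounds, and the source may have more. Where it says the series, first, only, none or still open, it means among the compounds named here.

Compound 1 `Cc1n[nH]c(C(=O)O)c1Cc1cccc(C(N)=O)c1` was tested in an assay on isolated protein for inhibition of 2-Hydroxyacid oxidase 2 (Rattus norvegicus) (on this read-out higher numbers stand for weaker inhibition and lower numbers for stronger inhibition), and gives 900 nM. For the measured compounds named here, the only other number comes from compound 2 `Cc1n[nH]c(C(=O)O)c1Cc1cccc(-c2ccc(C(=O)O)cc2)c1`, which in this assay gives 1100 nM, a result within the scatter of compound 1, so the two cannot be told apart. Compound 3 `Cc1n[nH]c(C(=O)O)c1Cc1cccc(OC(F)(F)F)c1` has not been measured; it differs from compound 1 by trifluoromethoxy in place of carbamoyl on an aromatic carbon. Going by the values given here, no measured pair shows such a change, so a small step toward weaker inhibition is expected, possibly none beyond the scatter. The step this expectation means is a 1.7-fold higher number from compound 1 to compound 3 (0.22 log units; within the scatter). Compound 3 is estimated at 1500 nM, with a range from 400 nM to 6000 nM.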

Compound 3, half-maximal inhibitory concentration: 700 nM
Beside the measured number, compound 3's estimate is 2.1-fold (0.33 log units) above it; the measured number falls inside the stated range.
By their numbers in this assay, from the lowest: compounds 3, 1 and 2 (each within the scatter of the next).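

In this assay, trifluoromethoxy in place of carbamoyl gives a 1.3-fold lower number from compound 1 to compound 3 (0.11 log units; within the scatter), so compound 1 and compound 3 cannot be told apart. On this aromatic carbon, then, the hydrogen-bond donor of carbamoyl can be lost, and a larger group with three fluorines can enter, without a change beyond the scatter. No measurement on hand explains why the number holds. Still open, as far as these compounds go, is whether an amine or a hydroxyl on this carbon would move the number beyond the scatter. Also open, from the compounds shown here alone, is what plain hydrogen there would give.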